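The compounds below may be only part of what the source reports. "The series", "measured", "known", "first", "only" and "open" are said of these compounds alone.

Working notes on the series.

Two members of the series carry a single chloro on the shared core. Compound 1 `ClCc1ccccc1Cn1cnc2c(Cl)ncnc21` and compound 2 `ClCc1cccc(Cn2cnc3ncnc(Cl)c32)c1` differ only in where the chloromethyl group sits on the benzyl ring. In a functional assay on OVCAR-4 cells (Homo sapiens) for cytotoxicity, read by sulforhodamine B assay, with a stated time of 48 h (on this read-out lower numbers stand for stronger inhibition of growth and higher numbers for weaker inhibition of growth), compound 1 gives 3380 nM, and in the same assay compound 2 gives 4160 nM. Compound 2 shows the higher of the two numbers, but the gap to compound 1 lies within the scatter, so the two values are read as equal and no word of order is placed between them.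

Compound 3 `ClCc1cccc(Cn2cnc3nc(Cl)nc(Cl)c32)c1` is not yet measured. It differs from compound 2 in one place: chloro in place of hydrogen on an aromatic carbon. The change is the entry of a second chloro on the core, on the aromatic carbon between two ring nitrogen atoms. For the measured compounds named here, no pair of measured compounds in this set shows what a change of this kind does, so there is no step on record to lean on. The expectation is therefore a modest step, if any, and the direction is left open; the estimated step is a 1.4-fold lower number from compound 2 to compound 3 (0.14 log units; within the scatter). For compound 3 the expected value in this assay is 3000 nM, with a range from 1100 nM to 8000 nM.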

Compound 3, concentration for 50% growth inhibition: 1580 nM
Compound 3: middle estimate off by 1.9-fold (0.28 log units), on the high side; the measured number falls inside the stated range.
By their numbers in this assay, from the lowest: compound 3; then compounds 1 and 2 (each within the scatter of the next).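

Chloro in place of hydrogen on the aromatic carbon between two ring nitrogen atoms gives, in this assay, a 2.6-fold lower number from compound 2 to compound 3 (0.42 log units; beyond the scatter) on the shared core, so this position answers to a change where the earlier pair showed none that could be read. The values of compound 1 and compound 2, which differ only in where the chloromethyl group sits on the benzyl ring, stand within the scatter of each other, and the present step is the only one in the series that lies beyond it. No measurement at hand bears on what lies behind this step, which is recorded here only as a difference in growth inhibition.

From the compounds shown here alone, whether the step belongs to chloro in particular stays open, and an amine, a methoxy group or a methyl group on the same aromatic carbon would answer that. Also open, going by these compounds, is whether the step carries over to the series with the chloromethyl group placed as in compound 1, and what a hydroxymethyl or a plain methyl group in place of chloromethyl would do to the numbers.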